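A Fluorine Added to the Aryl Ring of Compound 2

The source may hold more compounds than are shown below. What is called first, only, known or untested is meant among the compounds shown, and "the series" means these compounds.

Measured so far:
Compound 1 `COc1ccccc1/C=N\NC(=O)c1oc2cccc(O)c2c1C` gives 32700 nM in a functional assay on PC-3 cells (Homo sapiens) for inhibition; a higher number here means a weaker inhibitor, a lower number a stronger inhibitor.
Compound 2 `Cc1c(C(=O)N/N=C\c2ccccc2)oc2cccc(O)c12` gives 29200 nM in this assay.

Both compounds share one core and differ only in the ring attached through the hydrazone: the step of a 1.1-fold lower number from compound 1 to compound 2 (0.05 log units; within the scatter) replaces a methoxy on that ring with hydrogen. Compound 2 and compound 1 therefore sit within the usual scatter of each other, and neither can be called the stronger inhibitor on these two numbers.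

Compound 3 `Cc1c(C(=O)N/N=C\c2ccc(F)cc2)oc2cccc(O)c12` is the next step from compound 2: fluoro in place of hydrogen on an aromatic carbon. For the measured compounds named here, the single measured step offers the only guide, and it shows that swapping a group on this ring left the number in this assay essentially unchanged. Going by the values given here, no measured step involves a fluoro, so its effect is unknown. With so little to go on, the expectation is that the change from compound 2 to compound 3 stays within the scatter, giving an estimated step of a 1.0-fold lower number from compound 2 to compound 3 (0.00 log units; within the scatter). Compound 3 is thus expected to give about 29000 nM, with a likely range from 12000 nM to 70000 nM.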

Compound 3, half-maximal inhibitory concentration: >= 40000 nM
Compound 3 gave a limit, no number; the forecaster's own chance of this, stated with the estimate: 10%; at least 1.3-fold (0.13 log units) between middle value and limit.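

In this assay compound 3 is recorded as a limit and not as a number: the limit of >= 40000 nM in this assay, at which 1 of the 3 values shown sits.

Placing a fluoro para to a large group, the change from phenyl to 4-fluorophenyl, reads as an at least 1.3-fold higher number from compound 2 to compound 3 (0.13 log units; that floor lies within the scatter), and the change from 2-methoxyphenyl to 4-fluorophenyl reads as an at least 1.2-fold higher number from compound 1 to compound 3 (0.08 log units; that floor lies within the scatter). For the compounds shown here, this adds something the earlier pair could not show: the first look at a halogen on this ring gives no sign of stronger inhibition, though both floors fall within the scatter, so compound 3 cannot be called weaker than compound 2 or compound 1 on these figures.

Going by these compounds, how far the true number of compound 3 lies from its limit stays open, and with it whether the fluoro matters at all here or only appears to leave the number where it was. Going by these compounds alone, also open is how an amine, a carboxylic acid or a chloro on the same carbon would behave, since hydrogen, methoxy and fluoro are the only groups compared on this ring so far.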